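This account rests on a few compounds, and the source may have more. Where it says the series, first, only, none or still open, it means among the compounds named here.

Measured so far in an ADME assay on HEp-2 cells (Homo sapiens) for cytotoxicity (a higher number here means that more compound is tolerated, a lower number that less compound is tolerated), on the shared core
compound 1 `CC(C)CCn1c(Cn2c(=O)n(C(C)C)c3ccccc32)nc2cc(C(C)(C)N)ccc21` gives 3270 nM
compound 2 `CC(C)CCn1c(Cn2c(=O)n(C(C)C)c3ccccc32)nc2cc(CF)ccc21` gives 37300 nM
compound 3 `CC(C)CCn1c(Cn2c(=O)n(C(C)C)c3ccccc32)nc2ccc(C#N)cc21` gives 10000 nM

Compound 3 stands second highest of these three numbers, clearly above compound 1 and clearly below compound 2. Compound 4 `CC(C)CCn1c(Cn2c(=O)n(C(C)C)c3ccccc32)nc2ccc(C(=O)O)cc21` carries carboxy in place of cyano on an aromatic carbon and is still to be tested. For the measured compounds named here, no measured step swaps either of these groups. Going by the values given here, the only guide is an 11-fold higher number from compound 1 to compound 2 (1.06 log units; beyond the scatter) in this assay and it involves other groups, so it shows that one swap on an aromatic carbon can shift the number a long way, but it does not set a direction here. A smaller shift is expected, leaning upward with little certainty: a 1.8-fold higher number from compound 3 to compound 4 (0.26 log units; within the scatter) as the estimated step. For compound 4 the estimate is 18000 nM with an expected range from 5000 nM to 60000 nM in this measurement.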

Compound 4, half-maximal cytotoxic concentration: 125000 nM
Estimate against measurement, compound 4: 6.9-fold (0.84 log units) below; measured number above the stated range.
By their numbers in this assay, from the lowest: compound 1; then compound 3; then compound 2; then compound 4.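

In this assay, carboxy in place of cyano on this aromatic carbon gives a 13-fold higher number from compound 3 to compound 4 (1.10 log units; beyond the scatter). The earlier compounds shown here showed a large shift only for a swap of other groups, whereas this step shows that a large upward move also comes from this exchange at this position, which adds a hydrogen-bond donor by the count of the two groups.

As far as these compounds go, whether an amide or a methyl ester on the same carbon would move the number as far remains open. Nothing shown accounts for the size of this step.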